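Replacing the 1,3-dimethylbutyl group of compound 3

The source may hold more compounds than are shown below. What is called first, only, known or untested is meant among the compounds shown, and "the series" means these compounds.

Of the compounds shown here, three with a shared core have been tested so far. In an ADME assay on Huh-7 cells (Homo sapiens) for cytotoxicity, with a stated time of 72 h (a lower number here means that less compound is tolerated, a higher number that more compound is tolerated), compound 1 (`CC(C)CCn1nc(-c2cccs2)c(O)c(C2=NS(=O)(=O)c3cc(NS(=O)(=O)C4CC4)ccc3N2)c1=O`) gives > 1000 nM as a limit and not as a number. In this assay compound 2 (`CC(C)CCn1nc(-c2cncs2)c(O)c(C2=NS(=O)(=O)c3cc(NS(C)(=O)=O)ccc3N2)c1=O`) gives > 33000 nM as a limit as well. In this assay compound 3 (`CC(C)CC(C)n1nc(-c2cccs2)c(O)c(C2=NS(=O)(=O)c3cc(NS(C)(=O)=O)ccc3N2)c1=O`) also gives a limit and not a number, namely > 33000 nM for this compound. Compound 3 therefore stands at the limit of > 33000 nM in this assay, at which 2 of the 3 values shown sit, and has no exact figure.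

Compound 4 (`CS(=O)(=O)Nc1ccc2c(c1)S(=O)(=O)N=C(c1c(O)c(-c3cccs3)nn(CC3(C(F)(F)F)CCC3)c1=O)N2`) keeps the shared core and the thiophen-2-yl group of compound 3. It carries (1-(trifluoromethyl)cyclobutyl)methyl in place of 1,3-dimethylbutyl on an aromatic nitrogen. The entering group brings one four-membered non-aromatic ring of carbon only and no net charge.

Among the measured compounds shown here, no measured pair of compounds differs in one place only, so no measured step shows what this swap does. In this assay the estimated move a number no higher from compound 3 to compound 4 (the limit leaves the size open) is expected to stay within the usual scatter. This expectation rests on compound 3, whose limit is > 33000 nM in this assay as measured. For compound 4 the half-maximal cytotoxic concentration is estimated at 33000 nM with an expected range from 12000 nM to 60000 nM.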

Compound 4, half-maximal cytotoxic concentration: > 1000 nM
Compound 4: only a limit was reported; the forecaster's own chance of this, stated with the estimate: 85%; the middle value lies beyond the limit too.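

In this assay compound 4 gives > 1000 nM as a limit and not as a number. Compound 3 gives > 33000 nM as a limit as well. With only these two limits, no step can be read between compound 3 and compound 4. The compounds shown leave open whether this swap of groups on the aromatic nitrogen changes the concentration tolerated at all.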